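The compounds below may be only part of what the source reports. "The series", "measured", "known", "first", "only" and "open" are said of these compounds alone.

Working notes on the series, followed in a functional assay on T-24 cells (Homo sapiens) for cytotoxicity, read by CCK-8 assay, with a stated time of 24 h; on this read-out lower numbers stand for stronger inhibition and higher numbers for weaker inhibition. In this assay compound 1 `C/C(=C\c1cc(-c2ccc(F)cc2)cs1)C(N)=O` gives > 50000 nM, which is a limit of the assay rather than a number. Compound 2 `C/C(=C\c1cc(-c2ccc(C#N)cc2)cs1)C(N)=O` gives > 50000 nM, again a limit. Compound 3 `C/C(=C\c1cc(-c2ccc(Cl)cc2)cs1)C(N)=O` gives > 50000 nM, also a limit. All three values thus sit at the limit of > 50000 nM in this assay, at which 3 of the 3 values shown sit. The steps with cyano for fluoro a step that the two limits leave unreadable from compound 1 to compound 2, chloro for fluoro a step that the two limits leave unreadable from compound 1 to compound 3 and chloro for cyano a step that the two limits leave unreadable from compound 2 to compound 3 are accordingly of unreadable size. Compound 4 `C=Cc1ccc(-c2csc(/C=C(\C)C(N)=O)c2)cc1` carries vinyl in place of chloro on an aromatic carbon. Among the compounds with values here, no measured step involves a vinyl group, so neither size nor direction can be read from the series. Compound 4 is expected to remain near the limit, estimated at 50000 nM (range 15000 nM to 200000 nM). This estimate means a step of a number no higher from compound 3 to compound 4 (the limit leaves the size open), expected within the scatter.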

Compound 4, half-maximal inhibitory concentration: > 50000 nM
Compound 4: a limit, no number (the forecaster's own chance of this, stated with the estimate: 80%); the middle value sits exactly at the limit.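

Compound 4 also sits at the limit, so its steps to compound 1, compound 2 and compound 3 cannot be read: the limit of > 50000 nM in this assay, at which 4 of the 4 values shown sit.

The compounds shown leave open whether any group at this place gives a measurable value, and how the four compounds rank.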